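Removing a Dimethylamino Group from a Nucleoside Analogue

The source may report more compounds than this note shows. Statements on the series, on what has been measured and on what is new or still open speak of the compounds shown alone.

In a functional assay (Homo sapiens) for inhibition of Nucleic Acid, tested at 100 uM (on this read-out higher numbers stand for more inhibition at the one concentration tested (going by the name of the read-out) and lower numbers for less inhibition), compound 1 `CN(C)c1nccc2c1ncn2[C@H]1C[C@H](O)[C@@H](CO)O1` gives 0%, the lowest of the two single numbers recorded. Compound 2 `CSc1nccc2c1ncn2C1O[C@H](CO)[C@@H](O)[C@H]1O` gives 24%, which stands higher than compound 1 by more than the usual scatter. Compound 3 `OC[C@H]1O[C@@H](n2cnc3cnccc32)[C@H](O)[C@@H]1O` has been measured twice and gives 13%; 1% (2 entries); the two repeats the several entries of compound 3 in this assay, 13%; 1% (2 entries) show how far one reading of this kind can wander from another.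

Compound 4 `OC[C@H]1O[C@@H](n2cnc3cnccc32)C[C@@H]1O` differs from compound 1 by hydrogen in place of dimethylamino on an aromatic carbon. Among the compounds with values here, no measured pair of compounds shows this change on its own, so the size of its effect is open. In this assay compound 4 is expected to give 5%, with a range from 0% to 20%. The step of a number 5 percentage points higher from compound 1 to compound 4 (within the scatter) is expected to remain within the usual scatter.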

Compound 4, a percentage reported as inhibition, at one concentration (the size of the read-out at that concentration, not a potency): 6%
The estimate for compound 4 lay 1 percentage points below the measured number; measured number inside the range.
By their numbers in this assay, from the lowest: compounds 1 and 4 (each within the scatter of the next); then compound 2.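

In this assay, putting hydrogen in place of dimethylamino on this aromatic carbon next to the ring nitrogen gives a number 6 percentage points higher from compound 1 to compound 4 (within the scatter). Within the data shown here, this pair gives the first direct look at the change, and removing the group moves the reading by no more than the scatter. Both numbers are low, so the pair says little about what this position can contribute, and repeats of one compound can differ noticeably: the several entries of compound 3 in this assay, 13%; 1% (2 entries)

From the compounds shown here alone, whether a primary amine or a chlorine atom on this carbon would shift the reading beyond the scatter stays open. Compound 2 differs from compound 1 in more than one place, so its higher number cannot be credited to any single group.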